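Methyl ether of the hydroxymethyl compound in the series

A few compounds are considered here, and "the series" means these few. Any claim that something is new, unique, unknown or untested is made for them only; others in the source may bear on it.

Going by the values given here, compound 2 `CCc1cccc2c(OC)c(-c3occ(C)c3CO)ccc12` is the only member of the series with a numerical result: in a functional assay on SK-BR-3 cells (Homo sapiens) for cytotoxicity, read by MTT assay, with a stated time of 72 h (on this read-out higher numbers stand for an effect only at larger amounts of compound and lower numbers for an effect already at smaller amounts), compound 2 gives 0.73 ug/mL. Compound 1 `CCc1cccc2c(OC)c(-c3occ(C)c3C(=O)NC)ccc12` carries a methylcarbamoyl group in the same place. In this assay compound 1 gives only a limit, > 10 ug/mL. Among the compounds with values here, the one measured step, an at least 13-fold lower number from compound 1 to compound 2 (1.13 log units; beyond the scatter), is large, though its size rests on (the limit of > 10 ug/mL in this assay, at which 1 of the 2 values shown sits). Compound 3 `CCc1cccc2c(OC)c(-c3occ(C)c3COC)ccc12` differs from compound 2 by methyl in place of hydrogen on an oxygen on a saturated carbon. Within the data shown here, no measured step concerns a change on the oxygen of the hydroxymethyl group; the step from compound 1 to compound 2 exchanged the whole group and bears only loosely on this one. A small step, if any, is expected in this assay, most likely toward a higher number. Compound 3 is therefore estimated at 1.5 ug/mL (range 0.4 ug/mL to 6 ug/mL), the expected step being a 2.1-fold higher number from compound 2 to compound 3 (0.31 log units; beyond the scatter).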

Compound 3, concentration for half-maximal effect: > 10 ug/mL
Compound 3: only a limit was reported (the forecaster's own chance of this, stated with the estimate: 15%); middle value at least 6.6-fold (0.82 log units) away from the limit.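

Methyl in place of hydrogen on the oxygen gives an at least 13-fold higher number from compound 2 to compound 3 (1.13 log units; beyond the scatter) in this assay, so this single change at the hydroxymethyl group is enough to lose the measurable effect seen for compound 2. Of the three compounds, only compound 2 has a number, which ties that effect to the free hydroxy group among the groups shown here; compound 1 and compound 3 both end at a limit, and the step between them cannot be read. The full size of the step from the hydroxy to the methoxy form also stays unknown, as it rests on a limit: the limit of > 10 ug/mL in this assay, at which 2 of the 3 values shown sit.

Open, as far as these compounds go, is whether an aminomethyl group or a carboxylic acid in place of hydroxymethyl would give a number in this assay. Also open, from the compounds shown here alone, is how a longer chain on the oxygen, such as ethyl, would read.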